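A few compounds are considered here, and "the series" means these few. Any claim that something is new, unique, unknown or untested is made for them only; others in the source may bear on it.

Measured so far in a functional assay on K562/Adr cells (Homo sapiens) for inhibition, read by MTT assay, with a stated time of 48 h; a higher number here means a weaker inhibitor, a lower number a stronger inhibitor:
- Compound 1 `Nc1ccc(-c2cn([C@@H]3CN[C@H](C(=O)Nc4ccc(Cl)c(C(F)(F)F)c4)C3)nn2)cn1`: 25200 nM
- Compound 2 `CCN1CCN(c2cc(NC(=O)[C@@H]3C[C@H](n4cc(-c5ccc6c(N)n[nH]c6c5)nn4)CN3)ccc2Cl)CC1`: 12600 nM

Compound 1 lies within the usual scatter of compound 2, so these two numbers cannot be ranked. Compound 3 `Nc1nc2ccc(-c3cn([C@@H]4CN[C@H](C(=O)Nc5ccc(Cl)c(C(F)(F)F)c5)C4)nn3)nc2s1` loses the 6-aminopyridin-3-yl group of compound 1 and carries a two-ring group instead, on an aromatic carbon of a five-membered aromatic ring with 3 nitrogen: a group of 10 heavy atoms (6 carbon, 3 nitrogen, 1 sulfur; one five-membered aromatic ring with 2 hetero atoms, one six-membered aromatic ring with 1 hetero atom) in place of a group of 7 heavy atoms (5 carbon, 2 nitrogen; one six-membered aromatic ring with 1 hetero atom), on an aromatic carbon. Within the data shown here, no measured pair shows this kind of change, so the data give no guide to its effect, and no step beyond the scatter is expected in this assay, in either direction. The expected change is a 1.3-fold lower number from compound 1 to compound 3 (0.10 log units; within the scatter). Compound 3 is estimated at 20000 nM, within an expected range of 7000 nM to 50000 nM.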

Compound 3, half-maximal inhibitory concentration: 187000 nM
Estimate against measurement, compound 3: 9.4-fold (0.97 log units) below; the measured number lies above the stated range.
By their numbers in this assay, from the lowest: compounds 2 and 1 (each within the scatter of the next); then compound 3.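

In this assay, among these compounds, the group on this aromatic carbon of the five-membered aromatic ring with 3 nitrogen does matter: replacing 6-aminopyridin-3-yl with the two-ring group containing sulfur gives a 7.4-fold higher number from compound 1 to compound 3 (0.87 log units; beyond the scatter) and is the first change here to go beyond the scatter. This is a single pair, so it shows a weaker inhibitor for this one group and sets no general rule. No measurement shown here explains the step. On these data alone, it remains open whether the second ring or the sulfur goes with the weaker inhibition, and how a plain phenyl ring or a methoxy group on the pyridine ring would read at this position.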